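Removing a Methyl From a Weak Methoxyphenyl Analogue

A few compounds are considered here, and "the series" means these few. Any claim that something is new, unique, unknown or untested is made for them only; others in the source may bear on it.

Compound 1 `COc1ccc(-c2cc(O)c3c(C)cc(C)nc3n2)cc1` gives 91200 nM in a functional assay on U-251 cells (Homo sapiens); a higher number here means a weaker inhibitor of growth, a lower number a stronger inhibitor of growth. Compound 2 `COc1cccc(-c2cc(O)c3c(C)cc(C)nc3n2)c1` has the same atoms joined differently; how the two cores differ is not broken down here, but in this assay compound 2 gives 170 nM. Compound 3 `COc1cccc(-c2cc(O)c3c(C)ccnc3n2)c1` gives 58.9 nM in this assay; the change from compound 2 is hydrogen in place of methyl on an aromatic carbon, which made a 2.9-fold lower number from compound 2 to compound 3 (0.46 log units; beyond the scatter). Compound 4 `COc1ccc(-c2cc(O)c3ccc(C)nc3n2)cc1` is not yet measured and differs from compound 1 by hydrogen in place of methyl on an aromatic carbon. This is the same kind of change, not the same: in compound 3 the hydrogen sits next to the ring nitrogen and para to a fused ring, while in compound 4 it sits opposite the ring nitrogen and ortho to a fused ring. Resting only on that earlier step, for compound 4 a step of a 2.3-fold lower number from compound 1 to compound 4 (0.36 log units; beyond the scatter) is expected in this assay. Compound 4 is therefore estimated at 40000 nM, between 10000 nM and 130000 nM.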

Compound 4, concentration for 50% growth inhibition: > 100000 nM
Compound 4: only a limit was reported; the forecaster's own chance of this, stated with the estimate: 20%; middle value at least 2.5-fold (0.39 log units) away from the limit.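

In this assay compound 4 gives > 100000 nM, which is a limit of the assay and not a number, so the true size of the change on this core stays unknown: the limit of > 100000 nM in this assay, at which 1 of the 4 values shown sits.

Read with that floor, hydrogen in place of methyl gives an at least 1.0-fold higher number from compound 1 to compound 4 (0.04 log units; that floor lies within the scatter). The change therefore did not carry over with the same effect from one core to the other, although two pairs give no rule for the whole series and no reason for the gap: the same change on two cores in this assay, a 2.9-fold lower number (0.46 log units; beyond the scatter) from compound 2 to compound 3 and an at least 1.0-fold higher number (0.04 log units; that floor lies within the scatter) from compound 1 to compound 4, at least 3.1-fold (0.50 log units) apart, beyond the scatter of two such steps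

The compounds shown leave open what a longer chain such as ethyl, or an amine, would do on that same aromatic carbon in either core.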